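The source may report more compounds than this note shows. Statements on the series, on what has been measured and on what is new or still open speak of the compounds shown alone.

Measured so far:
compound 1 `C[C@@H]1N=C2C[C@@H]3C[C@@H](C3(C)C)[C@]2(C)OC1=O`: 149000 nM
compound 2 `CC1(C)[C@@H]2CC3=NCC(=O)O[C@@]3(C)[C@H]1C2`: 43000 nM

Among the compounds with values here, in a functional assay on PC-3 cells (Homo sapiens) for antiproliferative activity, read by sulforhodamine B assay, with a stated time of 48 h (on this read-out higher numbers stand for weaker inhibition and lower numbers for stronger inhibition), compound 1 gives 149000 nM, the highest of the two numbers; its nearest neighbour is compound 2, reached through the only measured step, a 3.5-fold lower number from compound 1 to compound 2 (0.54 log units; beyond the scatter). Compound 3 `CC(C)(C)OC(=O)CC[C@@H]1N=C2C[C@@H]3C[C@@H](C3(C)C)[C@]2(C)OC1=O` differs from compound 1 by (tert-butoxycarbonyl)methyl in place of hydrogen on a saturated chain carbon bound to a saturated ring carbon. That measured step removes a methyl from a ring carbon, whereas here a chain is added, so it gives no direct guide. Lacking a bearing comparison, compound 3 is expected to remain near compound 1 in this assay. For compound 3 the expected step is a 1.5-fold lower number from compound 1 to compound 3 (0.17 log units; within the scatter). Compound 3 is estimated at 100000 nM, range 30000 nM to 300000 nM.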

Compound 3, half-maximal inhibitory concentration: 42000 nM
The estimate for compound 3 lay 2.4-fold (0.38 log units) above the measured number; low and high end bracket the measured number.
By their numbers in this assay, from the lowest: compounds 3 and 2 (each within the scatter of the next); then compound 1.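

The step of a 3.5-fold lower number from compound 1 to compound 3 (0.55 log units; beyond the scatter) in this assay shows that this position accepts (tert-butoxycarbonyl)methyl without loss of activity. Together with a 3.5-fold lower number from compound 1 to compound 2 (0.54 log units; beyond the scatter) it means that both dropping the methyl and extending from that carbon give lower numbers than compound 1, and compounds 2 and 3 lie within the scatter of each other. No available evidence explains either step.

From the compounds shown here alone, what remains open is whether the tert-butyl ester matters or the chain alone suffices. A carboxylic acid or an amine at the chain end, or a longer chain, could separate the two.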